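Swapping an aminophenyl for a bromophenyl on the benzyl arm

The source may hold more compounds than are shown below. What is called first, only, known or untested is meant among the compounds shown, and "the series" means these compounds.

Measured so far:
Compound 1 `Cc1cccc(-c2cccc(NCc3cncn3Cc3ccccc3)c2)c1C` – > 1000 nM
Compound 2 `COC(=O)c1ccc(NCc2cncn2Cc2ccccc2N)cc1-c1ccccc1` – 25000 nM

Of the compounds shown here, two have been tested in a toxicity assay on NIH3T3 cells (Mus musculus) for cytotoxicity, read by resazurin assay; on this read-out higher numbers stand for an effect only at larger amounts of compound and lower numbers for an effect already at smaller amounts. For compound 1 the result is only a limit of the assay, > 1000 nM, and not a number. Among the measured compounds shown here, compound 2 gives 25000 nM in this assay, which is the only actual number among the two results. The other result, that of compound 1, is a limit, as noted in the limit of > 1000 nM in this assay, at which 1 of the 2 values shown sits. So compound 2 is the sole reference point with a measured value.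

Compound 3 `COC(=O)c1ccc(NCc2cncn2Cc2ccc(Br)cc2)cc1-c1ccccc1` has not been measured yet. It differs from compound 2 in one place: 4-bromophenyl in place of 2-aminophenyl on a saturated chain carbon bound to an aromatic nitrogen. The rest of the molecule, including the shared core, is unchanged.

For the measured compounds named here, no step between measured compounds is available to guide the expectation, since the only other result is a limit. The step from compound 2 to compound 3 is therefore expected to be small, a 1.3-fold lower number from compound 2 to compound 3 (0.10 log units; within the scatter), within the usual scatter of this assay. For compound 3 the estimate in this assay is 20000 nM, with a range from 6000 nM to 60000 nM.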

Compound 3, half-maximal effective concentration: > 10000 nM
Compound 3: no number, only a limit (the forecaster's own chance of this, stated with the estimate: 35%); the middle value lies beyond the limit too.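

No size can be read for the change from compound 2 to compound 3, because compound 3 gives no number, only a limit: the limit of > 10000 nM in this assay, at which 1 of the 3 values shown sits.

Left open is whether 4-bromophenyl in place of 2-aminophenyl shifts the amount of compound needed for an effect on these cells at all, and if so, by how much.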